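The source may hold more compounds than are shown below. What is called first, only, known or untested is meant among the compounds shown, and "the series" means these compounds.

Of the compounds shown here, three have so far been measured in a functional assay on EA.hy 926 cells (Homo sapiens) for cytotoxicity, read by MTT assay, with stated times of 24 h and 12 h; a higher number here means that more compound is needed for the effect, a lower number that less compound is needed. Compound 1 (`COc1ccc(/C=C/C(=O)O)c(OC(=O)c2nc(C)c(C)nc2C)c1`) gives 115000 nM, compound 3 (`CCOC(=O)/C=C/c1cc(OC)c(O)c(OC)c1`) gives 67200 nM, and compound 2 (`CCOC(=O)/C=C/c1ccc(OC(=O)c2nc(C)c(C)nc2C)c(O)c1`) gives 1700 nM. Compound 2 therefore has the lowest number of the three, and the gaps to both of the others lie beyond the scatter.

The next compound to be measured is compound 4 (`CCOC(=O)/C=C/c1ccc(OC(=O)c2nc(C)c(C)nc2C)c(OC)c1`), which departs from compound 2 in one place: methyl in place of hydrogen on an oxygen on an aromatic ring. Put briefly, the change turns hydroxy to methoxy.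

Going by the values given here, no measured pair shows this change on its own, so the expectation rests on indirect evidence. Compound 1 carries a methoxy group and sits far higher at 115000 nM, but it differs from compound 2 in more than one place. Compound 3 goes against any simple reading, since it carries both hydroxy and methoxy groups and still reaches 67200 nM.

A moderate rise in the number is expected, with an estimated 2.9-fold higher number from compound 2 to compound 4 (0.47 log units; beyond the scatter). For compound 4 the estimated value is 5000 nM, with an expected range from 1300 nM to 25000 nM.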

Compound 4, half-maximal effective concentration: 38600 nM
Compound 4: middle estimate off by 7.7-fold (0.89 log units), on the low side; the measured number lies above the stated range.
By their numbers in this assay, from the lowest: compound 2; then compounds 4, 3 and 1 (each within the scatter of the next, the first and the last beyond it).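

In this assay, going by these compounds alone, the change from hydroxy to methoxy gives a 23-fold higher number from compound 2 to compound 4 (1.36 log units; beyond the scatter) as the first measured pair in which this oxygen on an aromatic ring is altered on its own, and this large step lies beyond the scatter. Within this pair, a single added methyl with the rest of the structure unchanged is enough to lose most of the low number of compound 2, so that number depends on the hydrogen on this oxygen being in place, and the position does not tolerate even this small replacement. Nothing available explains why the step is so large, so it stands as a measured difference between these two compounds alone.

The compounds shown leave open whether the rise belongs to methyl in particular or to any loss of that hydrogen, which an ethoxy group, an acetoxy group, an amine or a fluorine at the same place would help to separate. Within the data shown here, they also leave open whether the same change from hydroxy to methoxy would give a step of similar size on a different core, as this single pair is the only reading of it.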